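The compounds below may be only part of what the source reports. "The series", "measured", "known", "first", "only" and "open" are said of these compounds alone.

Measured compounds:

Compound 1, `CC(C)c1ccc(OC(Cc2ccc(Cl)cc2)C(=O)O)cc1`: 10 mg/kg
Compound 2, `CC(C)(C)c1ccc(OC(Cc2ccc(Cl)cc2)C(=O)O)cc1`: 25 mg/kg
Compound 3, `CCCc1cccc(CC(C)(Oc2ccc(C(C)C)cc2)C(=O)O)c1`: 1 mg/kg

All three were tested in a functional assay on the whole organism for inhibition, with Rattus norvegicus as the target; on this read-out higher numbers stand for an effect only at larger amounts of compound and lower numbers for an effect already at smaller amounts. Compound 1 gives 10 mg/kg and compound 2 gives 25 mg/kg. Compound 2 differs from compound 1 by methyl in place of hydrogen on a saturated chain carbon bound to an aromatic carbon and two saturated chain carbons, and this change gives a 2.5-fold higher number from compound 1 to compound 2 (0.40 log units; beyond the scatter). Compound 3, built on a different core, gives 1 mg/kg in this assay, the lowest of the three numbers; how its core differs from that of compound 1 is not broken down here.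

Compound 4, `CCCCc1cccc(CC(C)(Oc2ccc(C(C)C)cc2)C(=O)O)c1`, has not yet been measured. It differs from compound 3 by methyl in place of hydrogen on a saturated chain carbon, three bonds along the chain from an aromatic carbon. Within the data shown here, this is the same kind of change as the one from compound 1 to compound 2, but not the same: there the added methyl sits on a saturated chain carbon bound to an aromatic carbon and two saturated chain carbons, here it sits on a saturated chain carbon, three bonds along the chain from an aromatic carbon, as the chain grows from propyl to butyl. Among the measured compounds shown here, because the only comparable step, a 2.5-fold higher number from compound 1 to compound 2 (0.40 log units; beyond the scatter), is modest and was made at a different place, only a small step is expected here, a 1.5-fold higher number from compound 3 to compound 4 (0.18 log units; within the scatter), likely within the scatter. Compound 4 is therefore expected to give about 1.5 mg/kg in this assay, estimated to fall between 0.5 mg/kg and 4 mg/kg.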

Compound 4, dose for half-maximal effect: 1 mg/kg
Estimate against measurement, compound 4: 1.5-fold (0.18 log units) above, and the stated range covers the measured number.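

In this assay, growing the propyl chain to butyl gives no change at the digits printed from compound 3 to compound 4 (within the scatter), so this added methyl leaves the number where it was. Set beside the earlier step, in which a methyl also replaces a hydrogen, the two results cannot be told apart: the same change on two cores in this assay, a 2.5-fold higher number (0.40 log units; beyond the scatter) from compound 1 to compound 2 and no change at the digits printed (within the scatter) from compound 3 to compound 4, 2.5-fold (0.40 log units) apart, within the scatter of two such steps. Among these compounds, this shows no sign that moving to another core alters the outcome of adding a methyl, but it does not prove that the outcome carries over, as there are only two steps and the methyl sits at a different place in each.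

The compounds shown leave open whether the methyl that separates compound 1 from compound 2 would give the same step if added at that place on the core of compound 3. They also leave open how a longer chain such as pentyl, or an amine in place of the butyl chain, would read in this assay.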